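Removing a Fluoro Group From a Slowly Cleared Compound

This account rests on a few compounds, and the source may have more. Where it says the series, first, only, none or still open, it means among the compounds named here.

Measured so far:
- compound 1 `C[C@H](Oc1cc2cc(C(N)=O)cc(F)c2nc1N)c1ncc(F)cc1-n1cccn1`, in an ADME assay on cells (Hepatocyte, Homo sapiens) for metabolic stability (on this read-out higher numbers stand for fast clearance and lower numbers for slow clearance), compound 1 gives 4 uL/min
- compound 2 `C[C@H](Oc1cc2cc(C#N)ccc2nc1N)c1cc(F)ccc1-n1cccn1`, in this assay compound 2 gives 40 uL/min

Compound 1 has the lowest number of the two; compound 2 sits far higher, beyond the usual scatter. Compound 3 `C[C@H](Oc1cc2cc(C(N)=O)ccc2nc1N)c1ncc(F)cc1-n1cccn1` differs from compound 1 in one place: hydrogen in place of fluoro on an aromatic carbon. Among the measured compounds shown here, no measured pair shows this exact change, so its effect is unknown here. In this assay compound 3 is expected to move only a little, perhaps toward slightly faster clearance, roughly a 1.5-fold higher number from compound 1 to compound 3 (0.18 log units; within the scatter). The expected value of compound 3 is 6 uL/min, within 2.5 uL/min to 15 uL/min.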

Compound 3, intrinsic clearance in a liver preparation (reported as CLH), per the amount of preparation that the assay uses in the Hepatocyte assay: < 2 uL/min
Compound 3 gave a limit, no number; the forecaster's own chance of this, stated with the estimate: 10%; middle value at least 3.0-fold (0.47 log units) away from the limit.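

In the Hepatocyte assay, hydrogen in place of fluoro on this aromatic carbon, ortho to a fused ring, gives an at least 2.0-fold lower number from compound 1 to compound 3 (0.30 log units; that floor lies within the scatter), so losing the fluoro brings no faster clearance in this pair. Compound 3 reads as a limit of the assay, not a number: the limit of < 2 uL/min in the Hepatocyte assay, at which 1 of the 3 values shown sits.

In a physicochemical assay for lipophilicity, using the shake flask method (on this read-out lower numbers stand for lower lipophilicity and higher numbers for higher lipophilicity), compound 1 gives 2.1 and compound 3 gives 1.9, a pair within the usual scatter.

The compounds shown leave open how a chloro or methoxy group on this same carbon would read in the Hepatocyte assay. They also leave open whether the same swap would behave alike on a core carrying a nitrile, as compound 2 does.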